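The source may hold more compounds than are shown below. What is called first, only, known or untested is meant among the compounds shown, and "the series" means these compounds.

Measured compounds in the series:

compound 1, `COc1ccc(-c2nc3ccccn3c2/C=C/C(=O)c2cc(OC)c(OC)c(OC)c2)cc1`, 32900 nM in a functional assay on MOLT-4 cells (Homo sapiens) for inhibition, read by sulforhodamine B assay, with a stated time of 48 h; a higher number here means a weaker inhibitor of growth, a lower number a stronger inhibitor of growth
compound 2, `COc1cc(C(=O)/C=C/c2c(-c3cccs3)nc3ccccn23)cc(OC)c1OC`, 1770 nM in this assay
compound 3, `COc1cc(C(=O)/C=C/c2c(-c3ccc(F)cc3)nc3ncccn23)cc(OC)c1OC`, 3750 nM in this assay

Compound 3 stands second highest of the three numbers in this assay: compound 2 gives the nearest value, a step beyond the scatter below it, and compound 1 gives the furthest, well above it.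

Compound 4 is `COc1ccc(-c2nc3ncccn3c2/C=C/C(=O)c2cc(OC)c(OC)c(OC)c2)cc1`, not yet measured. It differs from compound 3 in one place: methoxy in place of fluoro on an aromatic carbon. Among the measured compounds shown here, no measured pair shows this exact change. For the measured compounds named here, the one step that bears on it is a 19-fold lower number from compound 1 to compound 2 (1.27 log units; beyond the scatter), where the compound carrying 4-methoxyphenyl gives by far the highest number of the set. Compound 1 and compound 3 differ in two places, so their gap cannot be read as a single step, but the 4-methoxyphenyl compound again sits at the weak end.

Compound 4 is therefore expected to give a higher number than compound 3, with a step of about a 3.2-fold higher number from compound 3 to compound 4 (0.51 log units; beyond the scatter), a moderate rise. The estimate for compound 4 in this assay is 12000 nM, with a range from 4000 nM to 40000 nM.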

Compound 4, concentration for 50% growth inhibition: 3100 nM
For compound 4 the middle estimate is 3.9-fold (0.59 log units) above the measured one; measured number below the stated range.
By their numbers in this assay, from the lowest: compounds 2, 4 and 3 (each within the scatter of the next, the first and the last beyond it); then compound 1.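

On the core shared by compound 3 and compound 4, 4-methoxyphenyl in place of 4-fluorophenyl leaves the growth-inhibition read-out within the scatter, with a 1.2-fold lower number from compound 3 to compound 4 (0.08 log units; within the scatter) in this assay, so on this core the methoxy group does not by itself put a compound at the weak end. The high number of compound 1 (32900 nM) therefore cannot be read as a simple mark of 4-methoxyphenyl, since compound 4, which carries the same group on a different core, gives 3100 nM in the same assay. No measurement offered here explains why this change leaves the number in place.

As far as these compounds go, the effect of 4-fluorophenyl on the core of compound 1 remains open, and with it whether the same change would stay within the scatter there. Also open, from the compounds shown here alone, is whether a dimethylamino group or a carboxylic acid in this place, on the core of compound 3, would shift the number.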